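Cyclopentyl to 2-chlorophenyl on a shared core

The source may hold more compounds than are shown below. What is called first, only, known or untested is meant among the compounds shown, and "the series" means these compounds.

In a functional assay on HCT-116 cells (Homo sapiens) for antiproliferative activity, read by MTT assay, with a stated time of 72 h (a higher number here means a weaker inhibitor, a lower number a stronger inhibitor), compound 1 `O=C(Nc1ccc(Nc2nccc(NC3CCCCC3)n2)cc1)Nc1ccc(Cl)c(C(F)(F)F)c1` gives 5950 nM, compound 2 `O=C(Nc1ccc(Nc2nccc(NC3CCCC3)n2)cc1)Nc1ccc(Cl)c(C(F)(F)F)c1` gives 2510 nM and compound 3 `CCCNc1ccnc(Nc2ccc(NC(=O)Nc3ccc(Cl)c(C(F)(F)F)c3)cc2)n1` gives 4240 nM. Compound 2 sits at the low end of this small set, though not clear of its nearest neighbour: the measured steps are a 1.7-fold higher number from compound 2 to compound 3 (0.23 log units; within the scatter) and a 2.4-fold lower number from compound 1 to compound 2 (0.37 log units; beyond the scatter). Compound 4 `O=C(Nc1ccc(Nc2nccc(Nc3ccccc3Cl)n2)cc1)Nc1ccc(Cl)c(C(F)(F)F)c1` carries 2-chlorophenyl in place of cyclopentyl on a nitrogen on an aromatic ring. For the measured compounds named here, the only guides are swaps among cyclopentyl, cyclohexyl and propyl, such as a 1.4-fold lower number from compound 1 to compound 3 (0.15 log units; within the scatter), and none of them brings in an aromatic ring. No step beyond the scatter is therefore expected in this assay, and the estimated step is a 1.1-fold lower number from compound 2 to compound 4 (0.06 log units; within the scatter). Compound 4 is expected at 2200 nM, with an estimated range of 650 nM to 7000 nM.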

Compound 4, half-maximal inhibitory concentration: 8100 nM
Beside the measured number, compound 4's estimate is 3.7-fold (0.57 log units) below it, and the stated range ends below it.
By their numbers in this assay, from the lowest: compounds 2, 3, 1 and 4 (each within the scatter of the next, the first and the last beyond it).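

With a 3.2-fold higher number from compound 2 to compound 4 (0.51 log units; beyond the scatter) in this assay, 2-chlorophenyl on this nitrogen gives up activity relative to cyclopentyl, the first aromatic ring seen at this position. With a 1.9-fold higher number from compound 3 to compound 4 (0.28 log units; within the scatter) and a 1.4-fold higher number from compound 1 to compound 4 (0.13 log units; within the scatter) it cannot be told apart from propyl or cyclohexyl, so only cyclopentyl stands clear of it. No measurement shown here explains this difference.

From the compounds shown here alone, whether the step follows from the aromatic ring itself or from its chlorine stays open. A plain phenyl on this nitrogen would separate the two.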